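Replacing the Piperidin-1-yl Group of Compound 3

This account rests on a few compounds, and the source may have more. Where it says the series, first, only, none or still open, it means among the compounds named here.

Three compounds sharing one core were examined for cytotoxicity. In a toxicity assay on Vero cells (Chlorocebus sabaeus) for cytotoxicity, read by MTT assay (on this read-out lower numbers stand for stronger inhibition and higher numbers for weaker inhibition), compound 1 `O=C(NC(=O)c1ccsc1NC(=O)c1ccc(S(=O)(=O)N2CCCCC2)cc1)OCC(F)(F)F` gave "nd" (no result reported). In this assay compound 2 `O=C(Nc1sccc1C(=O)Nc1ccccn1)c1ccc(S(=O)(=O)N2CCCCC2)cc1` likewise gave "nd" (no result reported). Only compound 3 `CCOC(=O)NC(=O)c1ccsc1NC(=O)c1ccc(S(=O)(=O)N2CCCCC2)cc1` returned a number, 18.6 ug/mL, which makes it the single reference point, with no measured neighbour against which to rank it.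

Compound 4 `CCOC(=O)NC(=O)c1ccsc1NC(=O)c1ccc(S(=O)(=O)Nc2ccc(F)cc2)cc1` has not yet been measured. It differs from compound 3 in one place: (4-fluorophenyl)amino in place of piperidin-1-yl on a sulfonyl sulfur. In words, (4-fluorophenyl)amino stands in place of piperidin-1-yl on a sulfonyl sulfur. No measured pair among these compounds shows what a change at this place does in this assay, so the expectation remains cautious and the range wide. The expected change is a 1.1-fold higher number from compound 3 to compound 4 (0.03 log units; within the scatter), an estimate that stays within the usual scatter and favours neither direction. For compound 4 the estimated value is 20 ug/mL, with the result expected to fall between 6 ug/mL and 70 ug/mL.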

Compound 4, half-maximal inhibitory concentration: 20.5 ug/mL
Compound 4: middle estimate off by 1.0-fold (0.01 log units), on the low side, and the stated range covers the measured number.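

For the compounds shown here, the pair of compound 3 and compound 4 gives the first measured step at this place: in this assay the step is a 1.1-fold higher number from compound 3 to compound 4 (0.04 log units; within the scatter), so the sulfonyl sulfur carries either group with values that cannot be told apart. This holds even though the non-aromatic piperidin-1-yl ring gives way to (4-fluorophenyl)amino, with its aromatic ring and its hydrogen-bond donor. Nothing in hand bears on why the two groups read alike.

This single pair leaves open whether the same holds for other groups on the sulfonyl sulfur, such as phenylamino without its fluorine, morpholin-4-yl or a group carrying a carboxylic acid. Compounds 1 and 2 give no number, so nothing can be said about changes elsewhere on the shared core.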